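This account rests on a few compounds, and the source may have more. Where it says the series, first, only, none or still open, it means among the compounds named here.

Measured compounds in a functional assay on NUGC-3 cells (Homo sapiens) for cytotoxicity, read by sulforhodamine B assay, with a stated time of 72 h; on this read-out lower numbers stand for stronger inhibition of growth and higher numbers for weaker inhibition of growth:
- compound 1 `O=C(Nc1ccccc1C(F)(F)F)C1CCc2ccccc2N1`: 39300 nM
- compound 2 `O=C(Nc1ccccc1O)C1CCc2ccccc2N1`: 2680 nM
- compound 3 `O=C(Nc1ccccc1)C1CCc2ccccc2N1`: 59000 nM

Compound 1 holds the second highest of the three numbers. Its nearest neighbour is compound 3, with a 1.5-fold higher number from compound 1 to compound 3 (0.18 log units; within the scatter); its furthest is compound 2, with a 15-fold lower number from compound 1 to compound 2 (1.17 log units; beyond the scatter). The remaining pair shows a 22-fold higher number from compound 2 to compound 3 (1.34 log units; beyond the scatter).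

Compound 4 `O=C(Nc1ccccc1C(F)(F)F)C1CCc2ccccc2N1C(=O)c1ccccc1Cl` is not yet measured. It differs from compound 1 by (2-chlorophenyl)carbonyl in place of hydrogen on a nitrogen on an aromatic ring in a ring. For the measured compounds named here, all three measured steps concern the substituent on the anilide aromatic ring; none touches the ring nitrogen of the shared core, so no measured step bears on this change, and the two large steps noted above give no guidance on its direction. In this assay the only defensible expectation is therefore a number close to that of compound 1, with a broad margin on both sides.

Compound 4 is estimated at 30000 nM (range 5000 nM to 100000 nM), which is an expected step of a 1.3-fold lower number from compound 1 to compound 4 (0.12 log units; within the scatter).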

Compound 4, concentration for 50% growth inhibition: 2730 nM
Beside the measured number, compound 4's estimate is 11-fold (1.04 log units) above it; the whole stated range lies above it.
By their numbers in this assay, from the lowest: compounds 2 and 4 (each within the scatter of the next); then compounds 1 and 3 (each within the scatter of the next).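

In this assay, the step at the ring nitrogen of the shared core is large: (2-chlorophenyl)carbonyl in place of hydrogen gives a 14-fold lower number from compound 1 to compound 4 (1.16 log units; beyond the scatter). For the compounds shown here, this is the first measured change at this nitrogen, so the read-out responds to more than the substituent on the anilide aromatic ring, and the hydrogen on this nitrogen is not needed for growth inhibition at this level. No measurement on hand bears on why the number moves at this position.

A single entering group cannot show whether the step belongs to the carbonyl, the aromatic ring or the chlorine; an acetyl group, an unsubstituted benzoyl group or a methyl group on the same nitrogen would separate these parts. Also open, from the compounds shown here alone, is whether (2-chlorophenyl)carbonyl gives a step of similar size when the anilide ring carries hydroxy instead of trifluoromethyl.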